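Working notes: bromo in place of chloro, compound 3

The source may hold more compounds than are shown below. What is called first, only, known or untested is meant among the compounds shown, and "the series" means these compounds.

Measured so far in a functional assay on SW-620 cells (Homo sapiens) for inhibition, read by MTT assay, with a stated time of 72 h; a higher number here means a weaker inhibitor, a lower number a stronger inhibitor:
- compound 1 `COc1cc(NC(C)CCCNC(=O)Nc2ccc(Br)cc2)c2ncccc2c1` gives 23000 nM as its value
- compound 2 `COc1cc(NC(C)CCCNC(=O)NNC(=O)Nc2ccc(Cl)cc2)c2ncccc2c1` gives 48000 nM as its value

Within the data shown here, compound 2 stands highest of the two numbers, making it the weaker inhibitor on these data, with compound 1 its only neighbour. Compound 3 `COc1cc(NC(C)CCCNC(=O)NNC(=O)Nc2ccc(Br)cc2)c2ncccc2c1` differs from compound 2 by bromo in place of chloro on an aromatic carbon. Among the measured compounds shown here, the only measured step, a 2.1-fold higher number from compound 1 to compound 2 (0.32 log units; beyond the scatter), is modest and exchanges the halogen together with the rest of that group. For the measured compounds named here, no measured pair isolates bromo against chloro, so no step beyond the scatter is expected in this assay. The expected change is a 1.1-fold lower number from compound 2 to compound 3 (0.06 log units; within the scatter), slightly downward if anything. For compound 3 the estimated value is 42000 nM, with an expected range from 20000 nM to 85000 nM as its two ends.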

Compound 3, half-maximal inhibitory concentration: 17000 nM
Estimate against measurement, compound 3: 2.5-fold (0.39 log units) above; measured number below the stated range.
By their numbers in this assay, from the lowest: compounds 3 and 1 (each within the scatter of the next); then compound 2.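

In this assay, among these compounds, bromo in place of chloro on this aromatic carbon, para to a large group, gives a 2.8-fold lower number from compound 2 to compound 3 (0.45 log units; beyond the scatter) and is the first measured step that isolates the halogen, showing that this single-atom exchange is not silent. With bromo held fixed, the ((4-bromophenyl)carbamoyl)amino group in place of 4-bromophenyl on the amide-type nitrogen gives a 1.4-fold lower number from compound 1 to compound 3 (0.13 log units; within the scatter) and stays within the scatter, so at this halogen the two linkers cannot be told apart, unlike the mixed step that also exchanged the halogen. No available evidence accounts for the size of the halogen step.

As far as these compounds go, how fluoro, iodo or trifluoromethyl would read on this carbon stays open. From the compounds shown here alone, it also stays open whether the bromo and chloro difference holds on the shorter linker of compound 1.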